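Amide to sulfonamide on the shared core

The source may hold more compounds than are shown below. What is called first, only, known or untested is meant among the compounds shown, and "the series" means these compounds.

The series rests on one shared core, carried by compound 1 `COc1n[nH]c2ncc(-c3nnc(-c4c(F)ccc(NS(=O)(=O)c5cccc(Cl)c5)c4F)o3)cc12`, compound 2 `COc1n[nH]c2ncc(-c3cn(-c4cc(NS(=O)(=O)c5cccc(Cl)c5)ccc4F)nn3)cc12` and compound 3 `COc1n[nH]c2ncc(-c3cn(-c4c(F)ccc(NC(=O)c5cccc(Cl)c5)c4F)nn3)cc12`. In an assay on Sf9 cells for inhibition of mitogen-activated protein kinase kinase kinase 20 (Homo sapiens), read by ADP-Glo, with a stated time of 30 min (a lower number here means a stronger inhibitor, a higher number a weaker inhibitor), compound 1 gives 63.3 nM, compound 2 gives 5.7 nM and compound 3 gives 54.3 nM. Compound 3 therefore stands second highest of the three numbers: its value and that of compound 1 lie within the scatter of each other, while compound 2 sits well below both, beyond the scatter.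

The unmeasured compound 4 `COc1n[nH]c2ncc(-c3cn(-c4c(F)ccc(NS(=O)(=O)c5cccc(C)c5)c4F)nn3)cc12` differs from compound 3 in one place: (3-methylphenyl)sulfonyl in place of (3-chlorophenyl)carbonyl on a nitrogen on an aromatic ring. Going by the values given here, no measured pair isolates this change. Compound 2 and compound 1 both carry a sulfonyl group on that nitrogen and bracket a wide range, so the account expects compound 4 to land lower than compound 3, with the step of a 2.7-fold lower number from compound 3 to compound 4 (0.43 log units; beyond the scatter) judged moderate and uncertain in size. In this assay compound 4 is estimated at 20 nM, with a range from 5 nM to 80 nM.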

Compound 4, half-maximal inhibitory concentration: 4.4 nM
Estimate against measurement, compound 4: 4.5-fold (0.66 log units) above; measured number outside the range, below it.
By their numbers in this assay, from the lowest: compounds 4 and 2 (each within the scatter of the next); then compounds 3 and 1 (each within the scatter of the next).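

In this assay, going by these compounds alone, putting (3-methylphenyl)sulfonyl in place of (3-chlorophenyl)carbonyl on a nitrogen on an aromatic ring gives a 12-fold lower number from compound 3 to compound 4 (1.09 log units; beyond the scatter) as the first step that can be read, and a large one, so the group on this nitrogen can move the number a long way while the rest of compound 3 stays fixed. The swap alters two things at once, carbonyl to sulfonyl and chloro to methyl on the phenyl ring, and compound 3 and compound 4 alone cannot divide the step between them. Nothing given here explains the step.

The compounds shown leave open how (3-chlorophenyl)sulfonyl or (3-methylphenyl)carbonyl on the same nitrogen would read, which would separate the two parts of the swap. They also leave open what an amine or a carboxylic acid on that phenyl ring would do.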